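Piperazine side chain in place of piperidin-4-yl

The source may hold more compounds than are shown below. What is called first, only, known or untested is meant among the compounds shown, and "the series" means these compounds.

In an ADME assay on microsomes from liver (Mus musculus) for metabolic stability, read by LC-MS, with a stated time of 10 min, tested at 0.5 uM (a lower number here means that less of the compound is left, a higher number that more of the compound is left), compound 1 (`c1ccc2c(c1)CN[C@@H](CN(CCC1CCNCC1)[C@H]1CCCc3cccnc31)C2`) gives 32% as the lower of two measured numbers. Compound 2 (`c1cnc2c(c1)CCC[C@@H]2N(CCCN1CCNCC1)Cc1nc2ccccc2[nH]1`) gives 68% and stands above it beyond the scatter. Relative to compound 1, compound 3 (`c1ccc2c(c1)CN[C@@H](CN(CCCCN1CCNCC1)[C@H]1CCCc3cccnc31)C2`) carries 2-(piperazin-1-yl)ethyl in place of piperidin-4-yl on a saturated chain carbon, two bonds along the chain from an amine nitrogen. Going by the values given here, no measured step covers this change, so the expectation rests loosely on compound 2 at 68% with its piperazin-1-yl group. An upward move is expected, estimated at a number 18 percentage points higher from compound 1 to compound 3 (beyond the scatter) in size. For compound 3 the estimated value is 50% within an expected range of 30% to 72% for the coming measurement.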

Compound 3, percent of the compound remaining: 96%
For compound 3 the middle estimate is 46 percentage points below the measured one, and the stated range ends below it.
By their numbers in this assay, from the lowest: compound 1; then compound 2; then compound 3.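

In this assay the step of a number 64 percentage points higher from compound 1 to compound 3 (beyond the scatter) comes with 2-(piperazin-1-yl)ethyl in place of piperidin-4-yl on a saturated chain carbon, two bonds along the chain from an amine nitrogen. Going by these compounds alone, this is the first single-place comparison, and it shows that this position strongly affects the compound remaining on the shared core. Nothing available separates the contributions of ring and chain to this step, and no supporting data bear on its cause.

Still open, on these data alone, is whether a morpholin-4-yl or dimethylamino group at the end of the same chain would keep the number seen for compound 3. As far as these compounds go, a shorter chain carrying piperazin-1-yl on that core is equally open.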